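The source may report more compounds than this note shows. Statements on the series, on what has been measured and on what is new or still open speak of the compounds shown alone.

Working notes on the series, values from a functional assay on the whole organism with Rattus norvegicus as the target; a lower number here means that less compound is needed, a higher number that more compound is needed for the effect:

- compound 1 `COc1cc(N)c(Cl)cc1C(=O)NCCN(C)C(C)c1ccccc1`: 1 mg/kg
- compound 2 `CCN(CCNC(=O)c1cc(Cl)c(N)cc1OC)Cc1ccc(OC)cc1`: 0.2 mg/kg
- compound 3 `CCN(CCNC(=O)c1cc(Cl)c(N)cc1OC)Cc1ccc(Cl)cc1Cl`: 10 mg/kg

Within the data shown here, of these three numbers, the one for compound 1 is the second highest, with compound 2 lower and compound 3 higher. Compound 4 `COc1cc(N)c(Cl)cc1C(=O)NCCN(C)Cc1ccccc1C` has 2-methylbenzyl in place of 1-phenylethyl on an amine nitrogen. Among the measured compounds shown here, no measured step covers this exchange. For the measured compounds named here, the only measured step, a 50-fold higher number from compound 2 to compound 3 (1.70 log units; beyond the scatter), is large, but it replaces 4-methoxyphenyl with 2,4-dichlorophenyl. It therefore warns of a wide spread and gives no direction. The expected no change at the digits printed from compound 1 to compound 4 (within the scatter) is no shift beyond the scatter in this assay, though with wide uncertainty. For compound 4 the estimate is 1 mg/kg, with an expected range from 0.2 mg/kg to 5 mg/kg.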

Compound 4, dose for half-maximal effect: 2 mg/kg
The estimate for compound 4 lay 2.0-fold (0.30 log units) below the measured number, within the range that was stated.
By their numbers in this assay, from the lowest: compound 2; then compounds 1 and 4 (each within the scatter of the next); then compound 3.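

In this assay, 2-methylbenzyl in place of 1-phenylethyl on the amine nitrogen gives a 2.0-fold higher number from compound 1 to compound 4 (0.30 log units; within the scatter), so this exchange, with the same count of heavy atoms and one aromatic ring on each side, does not move the number beyond the scatter. The large earlier step had shown only that a change in this part of the series can matter; this one shows that a change here need not. Nothing available explains this result.

Open, going by these compounds, is whether a pyridine ring or a longer chain in place of 2-methylbenzyl on this nitrogen would leave the number equally unchanged.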